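The source may report more compounds than this note shows. Statements on the series, on what has been measured and on what is new or still open speak of the compounds shown alone.

Among the compounds with values here, compound 1 `O=C(CCC(=O)OCCCCCCSc1ccc([N+](=O)[O-])c2nonc12)Nc1ccccc1Cl` stands highest of the two numbers so far: in a functional assay on HOS cells (Homo sapiens) for inhibition, read by MTT assay, with a stated time of 72 h (a higher number here means a weaker inhibitor, a lower number a stronger inhibitor), compound 1 gives 335000 nM. Compound 2 `COc1ccc(NC(=O)CCC(=O)OCCCCCCSc2ccc([N+](=O)[O-])c3nonc23)cc1OC` gives 1390 nM in this assay, reached by a 240-fold lower number from compound 1 to compound 2 (2.38 log units; beyond the scatter). Compound 3 `O=C(CCC(=O)OCCCCCCSc1ccc([N+](=O)[O-])c2nonc12)NCCN1CCCC1` is not yet measured; it differs from compound 1 by 2-(pyrrolidin-1-yl)ethyl in place of 2-chlorophenyl on an amide-type nitrogen. Within the data shown here, the single measured step replaces one substituted phenyl with another and so bears on this change only loosely, though it shows that the group on the amide nitrogen can move this assay a great deal. A lowering is expected for compound 3, an 8.4-fold lower number from compound 1 to compound 3 (0.92 log units; beyond the scatter), giving an estimate of 40000 nM with a range from 4000 nM to 400000 nM.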

Compound 3, half-maximal inhibitory concentration: 3300 nM
Estimate against measurement, compound 3: 12-fold (1.08 log units) above, and the stated range ends above it.
By their numbers in this assay, from the lowest: compound 2; then compound 3; then compound 1.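

At this amide-type nitrogen, the drop in this assay is not confined to a substituted phenyl: 2-(pyrrolidin-1-yl)ethyl in place of 2-chlorophenyl gives a 100-fold lower number from compound 1 to compound 3 (2.01 log units; beyond the scatter) here. Set against the 3,4-dimethoxyphenyl group, the same amine-bearing chain gives a 2.4-fold higher number from compound 2 to compound 3 (0.38 log units; beyond the scatter), a modest gap beside the step from compound 1. Nothing available here accounts for either step.

Still open, on these data alone, is whether an unsubstituted phenyl would sit with compound 1 or with compound 2. A longer chain ending in pyrrolidine, or a morpholine in place of the pyrrolidine, would test how far the amine side tolerates change.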